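Piperazine-amide series on the shared core: methyl to methoxybenzyl

This account rests on a few compounds, and the source may have more. Where it says the series, first, only, none or still open, it means among the compounds named here.

Measured in a functional assay on MCF7 cells (Homo sapiens) for cytotoxicity, read by MTT assay, with a stated time of 24 h, tested at 6.4 ug/mL; a lower number here means a weaker effect, a higher number a stronger effect of the compound at the concentration tested:
compound 1 `Cn1c(-c2ccc(NC(=O)CSC3=NCCS3)cc2)nc(-c2ccccc2)c1-c1ccccc1`: 18.6%
compound 2 `CCN1CCN(CC(=O)Nc2ccc(-c3nc(-c4ccccc4)c(-c4ccccc4)n3C)cc2)CC1`: 16.4%

Compound 2 and compound 1 lie within the scatter of each other, so neither stands apart on these two numbers. Among the measured compounds shown here, the one measured step, a number 2.2 percentage points lower from compound 1 to compound 2 (within the scatter), exchanges the whole ring on the carbonyl-bound chain carbon and does not touch the place now changed. Compound 3 `COc1ccc(CN2CCN(CC(=O)Nc3ccc(-c4nc(-c5ccccc5)c(-c5ccccc5)n4C)cc3)CC2)cc1` carries 4-methoxyphenyl in place of methyl on a saturated chain carbon bound to an amine nitrogen in a ring. For the measured compounds named here, no measured step bears on this change, so nothing beyond the scatter is expected: the estimated step is a number 1.6 percentage points higher from compound 2 to compound 3 (within the scatter). Compound 3 is expected to give 18%, between 8% and 35%.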

Compound 3, a percentage reported as activity, at one concentration (the size of the read-out at that concentration, not a potency): 29%
Estimate against measurement, compound 3: 11 percentage points below, within the range that was stated.
By their numbers in this assay, from the lowest: compounds 2 and 1 (each within the scatter of the next); then compound 3.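

At this place, on a saturated chain carbon bound to an amine nitrogen in a ring, 4-methoxyphenyl in place of methyl gives in this assay a number 12.6 percentage points higher from compound 2 to compound 3 (beyond the scatter) and this is the only step shown that lies beyond the scatter. The position therefore accepts the larger aromatic group with a modest rise in the read-out at the one concentration tested. No available evidence accounts for this step.

Going by these compounds, whether the rise requires the methoxy group or only the aromatic ring remains open. An unsubstituted benzyl group at this place would separate the two.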